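Same atoms, rejoined: compound 1 to compound 4

The compounds below may be only part of what the source reports. "The series", "measured", "known", "first", "only" and "open" are said of these compounds alone.

In an ADME assay on microsomes from liver (Mus musculus, strain CD-1) for metabolic stability, read by LC-MS, with a stated time of 60 min, tested at 20 uM (a higher number here means that the compound lasts longer, a lower number that the compound disappears faster), compound 1 `CC(Sc1nc2nn(CC3COC3)cc2c(=O)n1-c1ccccc1)c1ccccc1` gives 0.317 h, the middle of three measured numbers: compound 2 `CC(Sc1nc2c(cnn2C)c(=O)n1-c1ccccc1)c1ccccn1` gives 0.833 h and compound 3 `CC(Sc1nc2c(cnn2C)c(=O)n1-c1ccccc1)c1cccc(O)c1` gives 0.0667 h. Compound 4 `CC(Sc1nc2nn(C3(C)COC3)cc2c(=O)n1-c1ccccc1)c1ccccc1` has the same atoms as compound 1, joined differently: 3-methyloxetan-3-yl in place of (oxetan-3-yl)methyl on an aromatic nitrogen. Within the data shown here, the only measured step, a 12-fold lower number from compound 2 to compound 3 (1.10 log units; beyond the scatter), was large, but it lies elsewhere, on a saturated chain carbon. It shows that one change can matter here, yet gives no direction for the group on the aromatic nitrogen. The starting point therefore stays compound 1 at 0.317 h, and no change beyond the scatter is expected. The expected step is a 1.1-fold higher number from compound 1 to compound 4 (0.04 log units; within the scatter). For compound 4 the estimated half-life is 0.35 h, with a range of 0.16 h to 0.75 h.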

Compound 4, half-life: > 1 h
Compound 4 ended at the assay's limit; the forecaster's own chance of this, stated with the estimate: 5%; middle value at least 2.8-fold (0.45 log units) away from the limit.
By their numbers in this assay, from the lowest: compound 3; then compound 1; then compound 2. At a limit, above all of these: compound 4.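

On the aromatic nitrogen, rejoining the same atoms from (oxetan-3-yl)methyl to 3-methyloxetan-3-yl gives an at least 3.1-fold higher number from compound 1 to compound 4 (0.49 log units; beyond the scatter) in this assay. So this position matters for how long the compound lasts, even though the two groups hold the same atoms and the same four-membered ring. The result for compound 4 is a limit of the assay, not a number: the limit of > 1 h in this assay, at which 1 of the 4 values shown sits.

From the compounds shown here alone, how far the half-life of compound 4 actually reaches stays open. So does whether a cyclobutyl group, with carbon in place of the ring oxygen, or an azetidine amine would behave alike on this nitrogen.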